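Trifluoromethyl for bromo on the sulfonyl aryl ring

The source may report more compounds than this note shows. Statements on the series, on what has been measured and on what is new or still open speak of the compounds shown alone.

Three compounds share one core and differ only in the group on the aryl ring attached to the sulfonyl sulfur. Compound 1 `O=S(=O)(c1cccc(F)c1)c1cn(C2CCNC2)c2ncccc12` carries a 3-fluorophenyl; in an assay on HeLa cells for displacement of a labelled ligand from 5-hydroxytryptamine receptor 6 (Homo sapiens) (a lower number here means a stronger inhibitor, a higher number a weaker inhibitor), compound 1 gives 2.7 nM. Compound 2 `O=S(=O)(c1ccc(F)cc1)c1cn(C2CCNC2)c2ncccc12` carries a 4-fluorophenyl, and in this assay compound 2 gives 8.5 nM. Compound 3 `O=S(=O)(c1cccc(Br)c1)c1cn(C2CCNC2)c2ncccc12` carries a 3-bromophenyl; in this assay compound 3 gives 1.3 nM, the lowest of the three numbers, with a 2.1-fold lower number from compound 1 to compound 3 (0.32 log units; beyond the scatter) and a 6.5-fold lower number from compound 2 to compound 3 (0.82 log units; beyond the scatter).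

Compound 4 `O=S(=O)(c1cccc(C(F)(F)F)c1)c1cn(C2CCNC2)c2ncccc12` is the next step: trifluoromethyl in place of bromo on an aromatic carbon. The change sits on an aromatic carbon of a six-membered aromatic ring of carbon only. Among the measured compounds shown here, no measured pair swaps bromo for trifluoromethyl, so the closest guide is the exchange of halogens at the same place, a 2.1-fold lower number from compound 1 to compound 3 (0.32 log units; beyond the scatter), which was modest. The step from fluoro to bromo lowered the number, so a second, larger group at the same place is expected to stay close to compound 3 or drift slightly upward rather than fall much further.

Compound 4 is therefore expected to give about 2 nM, within 0.7 nM to 6 nM, which is an expected step of a 1.5-fold higher number from compound 3 to compound 4 (0.19 log units; within the scatter).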

Compound 4, inhibition constant: 1.3 nM
Beside the measured number, compound 4's estimate is 1.5-fold (0.19 log units) above it, within the range that was stated.
By their numbers in this assay, from the lowest: compounds 3 and 4 (each within the scatter of the next); then compound 1; then compound 2.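

In this assay, the aromatic carbon meta to a large group accepts trifluoromethyl, with 4 heavy atoms, in place of bromo, with 1 heavy atom, and the outcome is no change at the digits printed from compound 3 to compound 4 (within the scatter), so this exchange leaves the reading unmoved even though the two groups share no atom. Fluoro is the group that stands apart at this place: there is a 2.1-fold lower number from compound 1 to compound 4 (0.32 log units; beyond the scatter), a modest step that matches a 2.1-fold lower number from compound 1 to compound 3 (0.32 log units; beyond the scatter), so two quite different groups both sit at the same modest distance from fluoro. Nothing in the available data explains why bromo and trifluoromethyl match here or why both differ from fluoro.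

Still open, as far as these compounds go, is whether the same match would hold at the ring position where compound 2 carries its fluoro, as bromo and trifluoromethyl appear in these compounds only at the place they share with compound 1. Also open is how this place would respond to a group of a different kind, such as an amine, a carboxylic acid or a longer carbon chain, as the groups shown here are only halogens and trifluoromethyl.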